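This account rests on a few compounds, and the source may have more. Where it says the series, first, only, none or still open, it means among the compounds named here.

Of the compounds shown here, three share one core and have been measured in a functional assay on the whole organism (strain albino) for inhibition, with Rattus norvegicus as the target, read by paw edema, with stated times of 30 min and 5 h, at a dose of 100 mg/kg by the oral route; a lower number here means less inhibition, a higher number more inhibition at the dose given (going by the name of the read-out). Compound 1 `COc1ccc(/C=C/C(=O)c2ccc(NC(=O)CO[N+](=O)[O-])cc2)cc1` gives 46%. Compound 2 `COc1ccc(/C=C/C(=O)c2ccc(NC(=O)COc3ccc(C(C)=O)cc3)cc2)cc1` gives 30%. Compound 3 `C/C(=N/O)c1ccc(OCC(=O)Nc2ccc(C(=O)/C=C/c3ccc(Cl)cc3)cc2)cc1` gives 49%, the highest number of the three, although its gap to compound 1 is within the scatter and only its gap to compound 2 is beyond it.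

Compound 4 `COc1ccc(/C=C/C(=O)c2ccc(NC(=O)COc3ccc(/C(C)=N\O)cc3)cc2)cc1` differs from compound 3 in one place: methoxy in place of chloro on an aromatic carbon. For the measured compounds named here, the only measured step, a number 16 percentage points lower from compound 1 to compound 2 (beyond the scatter), sits at another place in the shared core and does not bear on this change. Compound 1 and compound 2 both carry the methoxy that enters here, yet they differ from compound 4 elsewhere, so their numbers show nothing about the exchange of chloro for methoxy on its own. Going by the values given here, no measured step therefore speaks for a shift in either direction, and the expectation is a step no larger than the scatter.

Compound 4 is accordingly expected to give about 45%, with a likely range from 30% to 58%. This estimate corresponds to an expected step of a number 4 percentage points lower from compound 3 to compound 4 (within the scatter), which would leave compound 4 within the scatter of compound 3.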

Compound 4, a percentage reported as inhibition, in the whole organism at one dose (the size of the read-out at that dose, not a potency): 37%
Beside the measured number, compound 4's estimate is 8 percentage points above it, and the stated range covers the measured number.
By their numbers in this assay, from the lowest: compounds 2, 4, 1 and 3 (each within the scatter of the next, the first and the last beyond it).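

In this assay, for the compounds shown here, the exchange of chloro for methoxy on an aromatic carbon, para to a large group, gives a number 12 percentage points lower from compound 3 to compound 4 (beyond the scatter) and so provides the first evidence that this position can change the read-out, in a pair where the oxime-bearing end stays the same. At the other end of the molecule, with methoxy held in place, the group of 4 heavy atoms in place of the group of 3 heavy atoms gives a number 7 percentage points higher from compound 2 to compound 4 (within the scatter) and the group of 10 heavy atoms in place of the nitro-bearing group of 3 heavy atoms gives a number 9 percentage points lower from compound 1 to compound 4 (within the scatter), so compound 4 separates from neither neighbour, although compound 1 and compound 2 are separated from each other by the step printed earlier. Nothing measured here accounts for the effect of the methoxy-for-chloro exchange.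

As far as these compounds go, the effect at this position rests on a single pair, so it remains open whether fluoro, hydroxy or dimethylamino on the same aromatic carbon would track with chloro or with methoxy. From the compounds shown here alone, it also remains open whether the same exchange would give a step of similar size with the nitro or acetyl ends of compound 1 and compound 2 in place of the oxime.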